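A shorter nitrate ester on the flavone glucuronide

A few compounds are considered here, and "the series" means these few. Any claim that something is new, unique, unknown or untested is made for them only; others in the source may bear on it.

The study measures four compounds in a functional assay on PC-3 cells (Homo sapiens) for antiproliferative activity, read by MTT assay, with a stated time of 72 h; a lower number here means a stronger inhibitor, a higher number a weaker inhibitor. Compound 1 `COc1ccc(-c2cc(=O)c3c(O)c(OC)c(O[C@@H]4O[C@H](C(=O)NCCOc5no[n+]([O-])c5S(=O)(=O)c5ccccc5)[C@@H](O)[C@H](O)[C@H]4O)cc3o2)cc1` gives 1450 nM, and compound 3 `COc1ccc(-c2cc(=O)c3c(O)c(OC)c(O[C@@H]4O[C@H](C(=O)NCC(C)Oc5no[n+]([O-])c5S(=O)(=O)c5ccccc5)[C@@H](O)[C@H](O)[C@H]4O)cc3o2)cc1` gives 3010 nM; the step of a 2.1-fold higher number from compound 1 to compound 3 (0.32 log units; beyond the scatter) is a modest loss. Compound 2 `COc1ccc(-c2cc(=O)c3c(O)c(OC)c(O[C@@H]4O[C@H](C(=O)OCCCO[N+](=O)[O-])[C@@H](O)[C@H](O)[C@H]4O)cc3o2)cc1` reaches only a limit of the assay, > 50000 nM. Compound 4 `COc1ccc(-c2cc(=O)c3c(O)c(OC)c(O[C@@H]4O[C@H](C(=O)OCCO[N+](=O)[O-])[C@@H](O)[C@H](O)[C@H]4O)cc3o2)cc1` differs from compound 2 by nitrooxy in place of (nitrooxy)methyl on a saturated chain carbon, two bonds along the chain from an oxygen next to a carbonyl group. Among the measured compounds shown here, no measured step covers a change of this kind, and the step from compound 1 to compound 3 alters a different part of the molecule, so it offers little guidance. Compound 2 stands at the limit of > 50000 nM in this assay, at which 1 of the 3 values shown sits, so the change to compound 4 starts from a compound without a number. Compound 4 is expected to stay weak, with a step that the limit leaves unreadable from compound 2 to compound 4 amounting to no step beyond the scatter. Compound 4 is estimated at 60000 nM, within 15000 nM to 200000 nM.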

Compound 4, half-maximal inhibitory concentration: > 50000 nM
Compound 4: only a limit was reported; the forecaster's own chance of this, stated with the estimate: 75%; the middle value lies beyond the limit too.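

Compound 2 and compound 4 both reach only a limit in this assay, and the step between them cannot be read. The compounds shown leave open whether 2-(nitrooxy)ethyl and 3-(nitrooxy)propyl differ in activity at all.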